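This account rests on a few compounds, and the source may have more. Where it says the series, first, only, none or still open, it means among the compounds named here.

Measured compounds:
compound 1 `Cn1cc(-c2ccc(CN3CCC(O)(Cn4cnc5c(-c6ccc(CN)cc6)n(C)nc5c4=O)CC3)c(Cl)c2)cn1` — 291 nM
compound 2 `Cn1nc2c(=O)n(CC3(O)CCN(Cc4ccc(-c5ncco5)cc4Cl)CC3)cnc2c1-c1ccc(CN)cc1` — 1120 nM
compound 3 `Cn1nc2c(=O)n(CC3(O)CCN(Cc4ccc(-n5cccn5)cc4Cl)CC3)cnc2c1-c1ccc(CN)cc1` — 233 nM

In an assay on isolated protein for inhibition of ubiquitin carboxyl-terminal hydrolase 7 (Homo sapiens), with stated times of 30 min and 2 h (on this read-out higher numbers stand for weaker inhibition and lower numbers for stronger inhibition), compound 3 gives the lowest of the three numbers, though its gap to compound 1 is within the scatter a 1.2-fold lower number from compound 1 to compound 3 (0.10 log units; within the scatter); only compound 2 stands clearly apart a 4.8-fold lower number from compound 2 to compound 3 (0.68 log units; beyond the scatter). The three differ only in the five-membered aromatic ring attached to the benzene bearing the chloro group.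

Compound 4 `Cn1nc2c(=O)n(CC3(O)CCN(Cc4ccc(-c5ccsc5Cl)cc4Cl)CC3)cnc2c1-c1ccc(CN)cc1` changes that same ring: 2-chlorothiophen-3-yl in place of 1H-pyrazol-1-yl on an aromatic carbon. Within the data shown here, two measured steps bear on this kind of exchange. One was small a 1.2-fold lower number from compound 1 to compound 3 (0.10 log units; within the scatter), the other modest but clear a 3.8-fold higher number from compound 1 to compound 2 (0.59 log units; beyond the scatter). So swapping this ring can leave the number essentially unchanged or raise it noticeably, while no exchange so far has lowered it beyond the scatter. The new ring carries fewer hydrogen-bond acceptors than any of the three measured rings, so the outcome is uncertain; a somewhat higher number is expected in this assay a 2.1-fold higher number from compound 3 to compound 4 (0.33 log units; beyond the scatter). Compound 4 is estimated at 500 nM, with a range of 150 nM to 1700 nM.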

Compound 4, half-maximal inhibitory concentration: 453 nM
Beside the measured number, compound 4's estimate is 1.1-fold (0.04 log units) above it; the range from low to high includes it.
By their numbers in this assay, from the lowest: compounds 3, 1 and 4 (each within the scatter of the next); then compound 2.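

Compound 4 puts a ring holding sulfur and a chlorine but no nitrogen at this place, yet in this assay it cannot be told apart from the two pyrazole compounds (a 1.9-fold higher number from compound 3 to compound 4 (0.29 log units; within the scatter)) and (a 1.6-fold higher number from compound 1 to compound 4 (0.19 log units; within the scatter)), so among these compounds a ring nitrogen is not needed to stay in this range. The 1,3-oxazol-2-yl group of compound 2 now stands clearly apart from a third ring (a 2.5-fold lower number from compound 2 to compound 4 (0.39 log units; beyond the scatter)), which makes compound 2 the only one of the four with a clearly higher number. No measurement shown explains why the oxazole differs from the other rings.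

The compounds shown leave open what the chlorine on the thiophene adds, since plain thiophen-3-yl is not among them. As far as these compounds go, how a ring carrying an amine or a carboxylic acid would behave at this place also remains open.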